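The source may report more compounds than this note shows. Statements on the series, on what has been measured and on what is new or still open speak of the compounds shown alone.

Measured compounds in a functional assay on DLD-1 cells (Homo sapiens) for cytotoxicity, with a stated time of 48 h; on this read-out lower numbers stand for stronger inhibition and higher numbers for weaker inhibition:

Compound 1 `Cc1c(/C=C/[S+](C)[O-])oc2ccccc2c1=O` gives 7200 nM.
Compound 2 `CCC(=O)Oc1ccc2oc(/C=C/[S+](C)[O-])cc(=O)c2c1` gives 9000 nM.
Compound 3 `COc1ccc2c(=O)cc(/C=C/[S+](C)[O-])oc2c1` gives 7800 nM.

These three compounds share the same core carrying the same vinyl sulfoxide arm and differ only in what sits on the benzo ring. On the numbers shown, compound 2 stands together with compound 1 and compound 3: its gaps to each of them fall within the usual scatter of this assay, so no order among the three can be read from these values. The account now follows the step from compound 2 to compound 4 `CC(C)Oc1ccc2oc(/C=C/[S+](C)[O-])cc(=O)c2c1`, which has not yet been measured in this assay. The change is isopropyl in place of propanoyl on an oxygen on an aromatic ring. Compound 3 carries a methoxy at a similar place and its number sits within the scatter of compound 2, so a small alkyl ether in place of the ester is not expected to move the read-out beyond the scatter in either direction; the step of a 1.1-fold lower number from compound 2 to compound 4 (0.05 log units; within the scatter) is therefore expected to be no step beyond the scatter. Compound 4 is estimated to give 8000 nM in this assay, with a range from 3500 nM to 18000 nM.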

Compound 4, half-maximal inhibitory concentration: 8000 nM
Beside the measured number, compound 4's estimate shows no gap at the digits printed; the measured number falls inside the stated range.
By their numbers in this assay, from the lowest: compounds 1, 3, 4 and 2 (each within the scatter of the next).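

In this assay, among the compounds shown here, putting isopropyl in place of propanoyl on an oxygen on an aromatic ring gives a 1.1-fold lower number from compound 2 to compound 4 (0.05 log units; within the scatter) and is the first comparison in this set between compounds that differ in one place. It shows that, at this position, the read-out does not separate an ester from an ether: propanoyl brings a double bond outside aromatic rings and a hydrogen-bond acceptor, isopropyl brings neither, and the step stays within the scatter. No measurement shown here bears on why these two groups read alike.

The compounds shown leave open whether any group on this oxygen can move the number beyond the scatter, for instance a longer chain, a chain ending in an amine or a carboxylic acid, or a free hydroxyl in place of the whole substituent. They also leave open what replacing the vinyl sulfoxide arm would do, since every compound shown carries that arm and no step beyond the scatter appears among them.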